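A Larger Amine Arm on a Poorly Retained Scaffold

A few compounds are considered here, and "the series" means these few. Any claim that something is new, unique, unknown or untested is made for them only; others in the source may bear on it.

Compound 1 `Cc1csc2cc([C@H](C)Nc3ncnc(N)c3C#N)c(-c3cccc(CN4CCC(N(C)CC(C)C)CC4)c3)c(=O)n12` and compound 2 `Cc1csc2cc([C@H](C)Nc3ncnc(N)c3C#N)c(-c3cccc(CN(C)CCCN(C)Cc4ccc(Cl)cc4)c3)c(=O)n12` share one core and differ only in the amine-bearing side chain. In an ADME assay on the whole organism (lung, Rattus norvegicus) for metabolic stability, read by LC-MS, with a stated time of 24 h (a lower number here means that less of the compound is left, a higher number that more of the compound is left), compound 1 gives 2.8%, the lower of the two numbers, while compound 2 gives 3.3%; the gap between them lies within the scatter, so the two cannot be told apart. Compound 3 `Cc1csc2cc([C@H](C)Nc3ncnc(N)c3C#N)c(-c3cccc(CN4CCC(CN(C)Cc5ccccn5)CC4)c3)c(=O)n12` is a further member of the set, not yet measured. It differs from compound 1 in one place: (methyl((pyridin-2-yl)methyl)amino)methyl in place of isobutyl(methyl)amino on a saturated ring carbon. Among the measured compounds shown here, no measured pair shows what such a change does in this assay. Compound 1 gives 2.8% and compound 2 gives 3.3%, both small shares of the compound remaining, and compound 3 is expected to stay in the same region. The step of a number 1.2 percentage points higher from compound 1 to compound 3 (within the scatter) is expected to be no more than the scatter. Compound 3 is estimated to give 4%, with a range from 1% to 12%.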

Compound 3, percent of the compound remaining: 5.2%
Beside the measured number, compound 3's estimate is 1.2 percentage points below it, within the range that was stated.
By their numbers in this assay, from the lowest: compounds 1, 2 and 3 (each within the scatter of the next).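

In this assay, replacing isobutyl(methyl)amino with (methyl((pyridin-2-yl)methyl)amino)methyl on a saturated ring carbon gives the first step read at this position, a number 2.4 percentage points higher from compound 1 to compound 3 (within the scatter), and this is the only such change shown. The position therefore carries the larger arm, with its six-membered aromatic ring with 1 hetero atom, without a step beyond the scatter, and compound 3 stays in the same region as compound 1. Nothing available explains this result.

This single step cannot separate the contribution of the aromatic ring from that of the rest of the longer arm. The compounds shown leave open how a phenyl group in place of the pyridin-2-yl ring, or a morpholine on the same saturated ring carbon, would read in this assay at this position.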